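This account rests on a few compounds, and the source may have more. Where it says the series, first, only, none or still open, it means among the compounds named here.

Among the measured compounds shown here, in a functional assay on M21 cells (Homo sapiens) for antiproliferative activity, read by sulforhodamine B assay, with a stated time of 48 h (a higher number here means a weaker inhibitor, a lower number a stronger inhibitor), compound 2 (`O=C1NCCN1c1ccc(S(=O)(=O)Nc2ccc(Br)cc2)cc1`) gives 130 nM as the higher of the two numbers so far, and compound 1 (`Cc1cc(C)cc(NS(=O)(=O)c2ccc(N3CCNC3=O)cc2)c1`) gives 63 nM as the lower. Compound 3 (`Cc1ccccc1NS(=O)(=O)c1ccc(N2CCNC2=O)cc1`) remains unmeasured. It carries 2-methylphenyl in place of 4-bromophenyl on a sulfonamide nitrogen. For the measured compounds named here, only one measured step bears on this place, namely a 2.1-fold higher number from compound 1 to compound 2 (0.31 log units; beyond the scatter), a modest step that replaced 3,5-dimethylphenyl with 4-bromophenyl. Going by the values given here, no measured compound carries 2-methylphenyl, so this single step sets only the likely scale. Compound 3 shares methyl substitution with compound 1, which gives a slight lean toward a lower number in this assay without a firm expectation of a move beyond the scatter. The expected change is a 1.3-fold lower number from compound 2 to compound 3 (0.11 log units; within the scatter) on this reading. For compound 3 the estimated value is 100 nM, with an expected range from 30 nM to 350 nM as its ends.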

Compound 3, half-maximal inhibitory concentration: 150 nM
Estimate against measurement, compound 3: 1.5-fold (0.18 log units) below; low and high end bracket the measured number.
By their numbers in this assay, from the lowest: compound 1; then compounds 2 and 3 (each within the scatter of the next).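

In this assay, 2-methylphenyl in place of 4-bromophenyl on the sulfonamide nitrogen gives a 1.2-fold higher number from compound 2 to compound 3 (0.06 log units; within the scatter) and so leaves the number effectively unchanged, which means that a single methyl on the phenyl ring does not match the result of compound 1. The comparison with 3,5-dimethylphenyl gives a 2.4-fold higher number from compound 1 to compound 3 (0.38 log units; beyond the scatter) and, with the earlier step, sets 3,5-dimethylphenyl apart from both other groups at this position. Nothing shown here accounts for that separation.

The compounds shown do not settle whether the lower number of compound 1 depends on having two methyl groups or on where they sit on the ring. Also open, from the compounds shown here alone, is how this position responds to an amine, a carboxylic acid or a longer chain on the phenyl ring.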